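Chloro for fluoro on the longer-lived compound

The source may report more compounds than this note shows. Statements on the series, on what has been measured and on what is new or still open speak of the compounds shown alone.

Compound 1 `CC#C[C@@H](Cc1nnn[nH]1)c1ccc(OCc2ccc3sc(F)c(-c4ccccc4C)c3c2)cc1` and compound 2 `CC#C[C@@H](Cc1nnn[nH]1)c1ccc(OCc2ccc3scc(-c4ccc(OCCCS(C)(=O)=O)cc4C)c3c2)cc1` have both been measured in an ADME assay on the whole organism for metabolic stability, with Rattus norvegicus as the target, at a dose of 2 mg/kg by the intravenous route; a higher number here means that the compound lasts longer, a lower number that the compound disappears faster. Compound 1 gives 4.3 h, the higher of the two numbers, and compound 2 gives 1.5 h, a gap beyond the usual scatter. The two differ in more than one place, so this gap cannot be tied to any single group. Compound 3 `CC#C[C@@H](Cc1nnn[nH]1)c1ccc(OCc2ccc3sc(Cl)c(-c4ccccc4C)c3c2)cc1` departs from compound 1 in one place only: chloro in place of fluoro on an aromatic carbon. The new group is chloro in place of fluoro on an aromatic carbon, next to the ring sulfur. For the measured compounds named here, no measured pair shows a change at this place, so the data offer no direct precedent. In this assay no step beyond the scatter is expected, in either direction. The estimated change is a 1.0-fold higher number from compound 1 to compound 3 (0.02 log units; within the scatter). For compound 3 the expected half-life is 4.5 h, with an estimated range of 2.2 h to 9 h.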

Compound 3, half-life: 2.7 h
Estimate against measurement, compound 3: 1.7-fold (0.22 log units) above, within the range that was stated.
By their numbers in this assay, from the lowest: compounds 2, 3 and 1 (each within the scatter of the next, the first and the last beyond it).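

In this assay, the exchange of fluoro for chloro on the aromatic carbon next to the ring sulfur gives a 1.6-fold lower number from compound 1 to compound 3 (0.20 log units; within the scatter). For the compounds shown here, this is the first measured change at this place, and it shows that, on the core of compound 1, these two halogens cannot be told apart in this read-out. Nothing measured here bears on what lies behind this result.

As far as these compounds go, whether a hydrogen, a methyl group or a nitrile on this carbon would take the half-life beyond the scatter from compound 1 remains open. Going by these compounds alone, also open is how much of the gap between compound 1 and compound 2 belongs to this carbon and how much to the chain on the 2-methylphenyl group, since no single-place pair separates the two.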